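Piperazine nitrogen substituents on a shared quinazoline-type core

The source may hold more compounds than are shown below. What is called first, only, known or untested is meant among the compounds shown, and "the series" means these compounds.

Measured so far in an assay for binding affinity to Adrenergic receptor alpha-1 (Rattus norvegicus); a higher number here means a weaker inhibitor, a lower number a stronger inhibitor:
- compound 1, `COc1cc2nc(N3CCN(C(=O)COc4ccccc4)CC3)nc(N)c2cc1OC`: 12.6 nM
- compound 2, `COc1cc2nc(N3CCN(/C(S)=N/c4ccccc4)CC3)nc(N)c2cc1OC`: 0.00692 nM
- compound 3, `COc1cc2nc(N3CCN(/C(S)=N/c4ccc(NC(=S)N5CC5)cc4)CC3)nc(N)c2cc1OC`: 97.7 nM

Compound 2 stands lowest of the three numbers; its nearest neighbour is compound 1, with a 1800-fold lower number from compound 1 to compound 2 (3.26 log units; beyond the scatter), and its furthest is compound 3, with a 14000-fold higher number from compound 2 to compound 3 (4.15 log units; beyond the scatter).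

The unmeasured compound 4, `COc1cc2nc(N3CCN(S(=O)(=O)c4ccc(C)cc4)CC3)nc(N)c2cc1OC`, differs from compound 2 only at the ring nitrogen: a group of 10 heavy atoms (7 carbon, 2 oxygen, 1 sulfur; one six-membered aromatic ring of carbon only) in place of a group of 9 heavy atoms (7 carbon, 1 nitrogen, 1 sulfur; one six-membered aromatic ring of carbon only), on an amine nitrogen in a ring. Within the data shown here, of the two measured steps, only the one from compound 1 to compound 2 changes the group on that same amine nitrogen, and it was large, a 1800-fold lower number from compound 1 to compound 2 (3.26 log units; beyond the scatter). The step from compound 2 to compound 3 changes a different position and does not bear directly on compound 4. Both measured steps show that this series moves across very wide spans, so a large change is expected here too. Since compound 2 holds the lowest number and compound 1 gives 12.6 nM with a substituent of a different kind on that amine nitrogen, the expected direction for compound 4 is upward. The expected step is a 2200-fold higher number from compound 2 to compound 4 (3.34 log units; beyond the scatter). For compound 4 the estimate is 15 nM, within 1 nM to 200 nM.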

Compound 4, half-maximal inhibitory concentration: 11.5 nM
Compound 4: middle estimate off by 1.3-fold (0.12 log units), on the high side, within the range that was stated.
By their numbers in this assay, from the lowest: compound 2; then compounds 4 and 1 (each within the scatter of the next); then compound 3.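

In this assay, the change to (4-methylphenyl)sulfonyl on the amine nitrogen in the ring gives a 1700-fold higher number from compound 2 to compound 4 (3.22 log units; beyond the scatter) and so shows that a second replacement for the group of compound 2 at this position also ends far from it. The sulfonyl group and the (phenoxymethyl)carbonyl group cannot be told apart, with a 1.1-fold lower number from compound 1 to compound 4 (0.04 log units; within the scatter) as the printed step, so two different linking groups here give the same level. Among the compounds with an unsubstituted or methyl-only aromatic ring on this nitrogen, only compound 2 reaches the very low number, while compound 3 shows that its linking group alone does not secure that number.

As far as these compounds go, whether a urea with oxygen in place of the sulfur, or a simple benzyl group, would stay with compound 2 or join compounds 1 and 4 remains open. No measurement here offers an explanation for the gap between compound 2 and compound 4.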